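Swapping the amine substituent on a C-X-C chemokine receptor 1 binder

A few compounds are considered here, and "the series" means these few. Any claim that something is new, unique, unknown or untested is made for them only; others in the source may bear on it.

Compound 1: `CN(C)C(=O)c1cccc(Nc2n[s+]([O-])nc2N[C@@H](c2ccco2)C2(C)CC2)c1O`; 375 nM
Compound 2: `CC(C)[C@@H](NC1=NS(=O)(=O)N=C1Nc1cccc(C(=O)N(C)C)c1O)c1cccc(F)c1`; 652 nM

Of the compounds shown here, two have been measured in an assay on isolated protein for binding affinity to C-X-C chemokine receptor type 1 (Homo sapiens); on this read-out higher numbers stand for weaker inhibition and lower numbers for stronger inhibition. Compound 1 gives 375 nM, and compound 2 gives 652 nM; the gap between these two is within the scatter, so neither can be called stronger than the other. Compound 1 is the parent of the next step.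

Compound 3, `CC[C@@H](Nc1n[s+]([O-])nc1Nc1cccc(C(=O)N(C)C)c1O)c1ccccc1`, has not yet been measured. It differs from compound 1 in one place: 1-phenylpropyl in place of (furan-2-yl)(1-methylcyclopropyl)methyl on a nitrogen on an aromatic ring. The group that leaves is a bulkier two-ring piece with one hydrogen-bond acceptor; the group that enters is a simpler 1-phenylpropyl with none.

Going by the values given here, with no directly comparable step in hand, a modest move towards a higher number in this assay is expected for compound 3, the step from compound 1 being a 1.7-fold higher number from compound 1 to compound 3 (0.24 log units; within the scatter), though it could still fall within the scatter. The estimate for compound 3 is 650 nM, with a range from 200 nM to 2000 nM.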

Compound 3, inhibition constant: 1220 nM
Estimate against measurement, compound 3: 1.9-fold (0.27 log units) below, and the stated range covers the measured number.
By their numbers in this assay, from the lowest: compounds 1, 2 and 3 (each within the scatter of the next, the first and the last beyond it).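

In this assay, putting 1-phenylpropyl in place of (furan-2-yl)(1-methylcyclopropyl)methyl on the nitrogen gives a 3.3-fold higher number from compound 1 to compound 3 (0.51 log units; beyond the scatter). This shows that the number responds to the group at this position, which compounds 1 and 2 could not show, as they differ in more than one place. The change removes a three-membered ring, exchanges a five-membered aromatic ring with one hetero atom for a six-membered aromatic ring of carbon only, and loses the hydrogen-bond acceptor all at once, and nothing on hand explains the step.

As far as these compounds go, it remains open which of these differences matters: a phenyl(1-methylcyclopropyl)methyl group on the same nitrogen would separate the two rings' contributions. Also open, from the compounds shown here alone, is how a longer chain, such as 1-phenylbutyl, would compare with 1-phenylpropyl.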